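Nitro for Methyl: Expected Inhibition of Compound 4

A few compounds are considered here, and "the series" means these few. Any claim that something is new, unique, unknown or untested is made for them only; others in the source may bear on it.

Measured compounds:
- compound 1 `CCC(C)C(C(=O)Nc1ccc(C(C)=O)cc1)N(C(=O)c1ccccc1)S(=O)(=O)c1ccc(C)cc1`: 25.7%
- compound 2 `CC(=O)c1ccc(NC(=O)C2CC(O)CN2S(=O)(=O)c2ccc(C)cc2)cc1`: 12.5%
- compound 3 `CCC(C)C(C(=O)Nc1ccc(C(C)=O)cc1)N(C(=O)c1ccccc1)S(=O)(=O)c1ccc([N+](=O)[O-])cc1`: 31.7%

In a functional assay for inhibition, read by spectrophotometry, with a stated time of 20 min, tested at 2 mg/mL (on this read-out higher numbers stand for a stronger effect at the one concentration tested and lower numbers for a weaker effect), compound 2 gives the lowest of the three numbers, and its gap to compound 1 as well as its gap to compound 3 lies beyond the usual scatter of the assay. Compound 4 `CC(=O)c1ccc(NC(=O)C2CC(O)CN2S(=O)(=O)c2ccc([N+](=O)[O-])cc2)cc1` has not yet been measured. It differs from compound 2 by nitro in place of methyl on an aromatic carbon, the same difference that separates compound 1 from compound 3, where it reads 4-methylphenyl to 4-nitrophenyl.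

Among the compounds with values here, that pair is the only measured step bearing on the change: a number 6 percentage points higher from compound 1 to compound 3 (within the scatter), a shift that stays within the scatter. On this basis compound 4 is expected to give a number close to that of compound 2, the estimated step being a number 5.5 percentage points higher from compound 2 to compound 4 (within the scatter), leaning slightly upward but not beyond the scatter. Compound 4 is therefore estimated at 18%, with a range from 8% to 30%.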

Compound 4, a percentage reported as inhibition, at one concentration (the size of the read-out at that concentration, not a potency): 57%
Beside the measured number, compound 4's estimate is 39 percentage points below it; the measured number lies above the stated range.
By their numbers in this assay, from the lowest: compound 2; then compounds 1 and 3 (each within the scatter of the next); then compound 4.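

Nitro in place of methyl at this position does not act as a change of fixed size in this assay: on the core of compound 2 it brings a number 44.5 percentage points higher from compound 2 to compound 4 (beyond the scatter), the first step at this position to clear the scatter. The earlier pair alone could not show that the outcome of this change differs with the core that carries it: the same change on two cores in this assay, a number 6 percentage points higher (within the scatter) from compound 1 to compound 3 and a number 44.5 percentage points higher (beyond the scatter) from compound 2 to compound 4, 38.5 percentage points apart, beyond the scatter of two such steps The step describes the size of the effect at the one concentration tested, not a potency.

The compounds shown do not tell which difference between the two cores goes with the larger step. They also do not tell whether that step is particular to nitro, or how an amine or a carboxylic acid would read in the same place on the core of compound 2.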